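The source may hold more compounds than are shown below. What is called first, only, known or untested is meant among the compounds shown, and "the series" means these compounds.

Measured so far:
Compound 1 `Cn1c(CN2C[C@@H]3C(COc4cc(F)ccc4F)[C@@H]3C2)nc2ccccc21`; in an in vitro ADME assay on microsomes from liver (Homo sapiens) for metabolic stability, tested at 1 uM (a higher number here means faster removal of the compound, a lower number slower removal), compound 1 gives > 18.7 mL/min/kg, which is a limit of the assay and not a number.
Compound 2 `CC(C)c1ccc(OCC2[C@H]3CN(Cc4nc5ccccc5n4C)C[C@@H]23)cc1`; in this assay compound 2 gives 5.8 mL/min/kg.
Compound 3 `Cn1c(CN2C[C@@H]3C(COc4ccc(Cl)cc4)[C@@H]3C2)nc2ccccc21`; in this assay compound 3 gives 6.6 mL/min/kg.

Compound 3 thus holds the higher of the two numbers shown, with compound 2 its nearest neighbour and the two within the scatter of each other; the remaining value is a limit.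

Compound 4 `Cn1c(CN2C[C@@H]3C(COc4ccc(Cl)cc4F)[C@@H]3C2)nc2ccccc21` differs from compound 3 by fluoro in place of hydrogen on an aromatic carbon.

Going by the values given here, three measured steps bear on this. Both an at least 3.2-fold lower number from compound 1 to compound 2 (0.50 log units; beyond the scatter) and an at least 2.8-fold lower number from compound 1 to compound 3 (0.45 log units; beyond the scatter) replace the 2,5-difluorophenyl, which sits at the limit (the limit of > 18.7 mL/min/kg in this assay, at which 1 of the 3 values shown sits), by a phenyl carrying one group only, and both are at least modest in size. By contrast a 1.1-fold higher number from compound 2 to compound 3 (0.06 log units; within the scatter) shows that exchanging that single group leaves the number within the scatter. Among the compounds with values here, no measured step adds one fluoro to a phenyl that already carries a chloro, so the size of this move is not fixed by the data; compound 4 sits between compound 3 and the difluoro pattern of compound 1.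

The expectation is therefore a small rise in this assay, a 1.3-fold higher number from compound 3 to compound 4 (0.11 log units; within the scatter), that may stay within the scatter. Compound 4 is estimated at 8.5 mL/min/kg, in the range 4.5 mL/min/kg to 16 mL/min/kg.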

Compound 4, clearance: 6.9 mL/min/kg
Beside the measured number, compound 4's estimate is 1.2-fold (0.09 log units) above it; the range from low to high includes it.
By their numbers in this assay, from the lowest: compounds 2, 3 and 4 (each within the scatter of the next). At a limit, above all of these: compound 1.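

In this assay, fluoro in place of hydrogen on the aromatic carbon ortho to a large group and meta to the chloro group leaves the number within the scatter (a 1.0-fold higher number from compound 3 to compound 4 (0.02 log units; within the scatter)), so this position accepts fluoro on the 4-chlorophenyl without a readable change. Going by these compounds alone, compound 4 is also the first compound here with a second group on the phenyl that does not sit with compound 1: it stays within the scatter of the single-group 4-isopropylphenyl (a 1.2-fold higher number from compound 2 to compound 4 (0.08 log units; within the scatter)) and is clearly apart from the 2,5-difluorophenyl (an at least 2.7-fold lower number from compound 1 to compound 4 (0.43 log units; beyond the scatter)), so carrying two groups on the phenyl does not alone go with the high reading of compound 1. Compound 1 remains a limit of the assay and not a number: the limit of > 18.7 mL/min/kg in this assay, at which 1 of the 4 values shown sits.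

Whether fluoro at this position would be equally silent without the chloro group remains open, as the compounds shown include no 2-fluorophenyl alone. Also open, from the compounds shown here alone, is whether a larger group at the same place, such as methoxy or trifluoromethyl, or an amine, would keep the number in this range.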